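The compounds below may be only part of what the source reports. "The series", "measured", "known", "first", "only" and "open" are said of these compounds alone.

Compound 3 `O=C(Nc1nnc(-c2ccc3c(c2)OCCO3)s1)c1ccc(Cl)nc1` shares its core with compound 1 `O=C(Nc1nnc(-c2ccc3c(c2)OCCO3)s1)c1ccccc1` and compound 2 `O=C(CCc1ccccc1)Nc1nnc(-c2ccc3c(c2)OCCO3)s1`. In a functional assay on HeLa cells (Homo sapiens) for antiproliferative activity, read by MTT assay, with a stated time of 48 h (on this read-out lower numbers stand for an effect already at smaller amounts and higher numbers for an effect only at larger amounts of compound), compound 3 gives > 100 ug/mL, which is a limit of the assay rather than a number. Compound 1 likewise gives > 100 ug/mL, also a limit. Compound 2 gives 32.5 ug/mL. Compound 4 `O=C(/C=C/c1ccccc1)Nc1nnc(-c2ccc3c(c2)OCCO3)s1` differs from compound 3 in one place: 2-phenylethenyl in place of 6-chloropyridin-3-yl on a carbonyl carbon. Among the measured compounds shown here, two measured steps bear on this change. The step of an at least 3.0-fold lower number from compound 1 to compound 2 (0.48 log units; beyond the scatter) moved the number down, and the step of an at least 3.0-fold higher number from compound 2 to compound 3 (0.48 log units; beyond the scatter) moved it up again, so the 2-phenylethenyl group of compound 4, which resembles the phenethyl of compound 2 apart from its double bond, is expected to give a step of an at least 3.3-fold lower number from compound 3 to compound 4 (0.52 log units; beyond the scatter). Because (the limit of > 100 ug/mL in this assay, at which 2 of the 3 values shown sit), the size of that step is only partly readable. Compound 4 is therefore estimated at 30 ug/mL, within 10 ug/mL to 100 ug/mL.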

Compound 4, half-maximal effective concentration: > 100 ug/mL
Compound 4 gave a limit, no number (the forecaster's own chance of this, stated with the estimate: 20%); at least 3.3-fold (0.52 log units) between middle value and limit.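

On the carbonyl carbon, the double bond alone separates two otherwise matching groups, and exchanging phenethyl for 2-phenylethenyl in this assay gives an at least 3.0-fold higher number from compound 2 to compound 4 (0.48 log units; beyond the scatter). Among the compounds shown here, of the four compounds, only the one with phenethyl therefore gives a number, so having a link between the carbonyl and the phenyl ring does not by itself preserve the effect. The steps from compound 3 to compound 4 and from compound 1 to compound 4 cannot be read, since both ends of each are limits: the limit of > 100 ug/mL in this assay, at which 3 of the 4 values shown sit.

As far as these compounds go, whether a longer chain such as phenylpropyl would preserve the effect of compound 2 remains open.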